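The compounds below may be only part of what the source reports. "The series", "measured", "known", "first", "only" and "open" are said of these compounds alone.

Measured so far in a functional assay on OVCAR-3 cells (Homo sapiens) for inhibition, read by MTT assay, with a stated time of 24 h; on this read-out higher numbers stand for weaker inhibition and lower numbers for stronger inhibition:
- compound 1 `CC1(C)[C@H]2CC[C@]1(C)N(Cc1cn(-c3ccc(C#N)cc3)nn1)C(=O)C2` gives 380 nM
- compound 2 `CC1(C)[C@H]2CC[C@]1(C)N(Cc1cn(-c3ccccc3C#N)nn1)C(=O)C2` gives 110 nM
- compound 3 `CC1(C)[C@H]2CC[C@]1(C)N(Cc1cn(-c3ccccc3Cl)nn1)C(=O)C2` gives 40 nM

Compound 1 carries the highest number of the three. Its nearest neighbour is compound 2, reached by a 3.5-fold lower number from compound 1 to compound 2 (0.54 log units; beyond the scatter); the furthest is compound 3, reached by a 9.5-fold lower number from compound 1 to compound 3 (0.98 log units; beyond the scatter). Between those two, a 2.8-fold lower number from compound 2 to compound 3 (0.44 log units; beyond the scatter) shows the swap of a nitrile for a halogen on an aromatic carbon lowering the number beyond the scatter.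

Compound 4 `CC1(C)[C@H]2CC[C@]1(C)N(Cc1cn(-c3ccc(Br)cc3)nn1)C(=O)C2` is not yet measured. It differs from compound 1 by bromo in place of cyano on an aromatic carbon. Going by the values given here, no measured pair repeats exactly this change: the only halogen-for-nitrile comparison, compound 2 to compound 3, sits on a different aromatic carbon, and the two position changes from compound 1 both involve moving the group rather than replacing it. The halogen-for-nitrile step is nevertheless the closest guide, and it was modest. On that basis a modest fall in the number is expected for compound 4, roughly a 2.4-fold lower number from compound 1 to compound 4 (0.38 log units; beyond the scatter), with the chance that the change stays within the scatter.

The estimate for compound 4 in this assay is 160 nM, expected to lie between 60 nM and 420 nM.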

Compound 4, half-maximal inhibitory concentration: 140 nM
Compound 4: the middle estimate sits 1.1-fold (0.06 log units) above what was measured; measured number inside the range.
By their numbers in this assay, from the lowest: compound 3; then compounds 2 and 4 (each within the scatter of the next); then compound 1.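

In this assay, bromo in place of cyano on the aromatic carbon para to a large group gives a 2.7-fold lower number from compound 1 to compound 4 (0.43 log units; beyond the scatter) and so shows that a halogen-for-nitrile swap on the 4-substituted phenyl lowers the number, in the same direction as a 2.8-fold lower number from compound 2 to compound 3 (0.44 log units; beyond the scatter) on the 2-substituted phenyl. Moving from 2-cyanophenyl to 4-bromophenyl gives a 1.3-fold higher number from compound 2 to compound 4 (0.10 log units; within the scatter) and so does not separate these two groups, whereas a 3.5-fold higher number from compound 3 to compound 4 (0.54 log units; beyond the scatter) leaves compound 3 with the lowest number of the four and shows that a para bromo does not match the 2-chlorophenyl result. No supporting data bear on why the number falls with this change.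

The compounds shown never place bromo and chloro on the same aromatic carbon, so the identity of the halogen and its place on the phenyl ring remain entangled. Also open, on these data alone, is whether an amine, a methoxy group or a carboxylic acid on the same aromatic carbon would track with the halogens or with the nitrile.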